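Replacing the 3-chlorophenyl group of compound 2

This account rests on a few compounds, and the source may have more. Where it says the series, first, only, none or still open, it means among the compounds named here.

For the measured compounds named here, in a functional assay on a cell-free system (Platelet, plasma, Homo sapiens) for inhibition (on this read-out higher numbers stand for weaker inhibition and lower numbers for stronger inhibition), compound 2 (`Cc1ccc(N(CCN2CCC(OCC(=O)O)CC2)C(=O)c2cccc(Cl)c2)cc1`) gives 100 nM, the lower of the two numbers so far. Compound 1 (`COc1ccc(C(=O)N(CCN2CCC(OCC(=O)O)CC2)c2ccc(C)cc2)cc1`) gives 1200 nM. Compound 3 (`COc1cccc(C(=O)N(CCN2CCC(OCC(=O)O)CC2)c2ccc(C)cc2)c1OC`) carries 2,3-dimethoxyphenyl in place of 3-chlorophenyl on a carbonyl carbon. Going by the values given here, the one measured step at this place is a 12-fold lower number from compound 1 to compound 2 (1.08 log units; beyond the scatter), large and beyond the scatter, and it favoured 3-chlorophenyl over 4-methoxyphenyl. Among the compounds with values here, no measured compound carries 2,3-dimethoxyphenyl, so the reading is loose. The expected change is a 5.0-fold higher number from compound 2 to compound 3 (0.70 log units; beyond the scatter), toward a higher number and somewhat smaller than the measured step. The estimated value for compound 3 is 500 nM, with an expected range of 150 nM to 1500 nM.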

Compound 3, half-maximal inhibitory concentration: 1600 nM
Compound 3: the middle estimate sits 3.2-fold (0.51 log units) below what was measured; the measured number lies above the stated range.
By their numbers in this assay, from the lowest: compound 2; then compounds 1 and 3 (each within the scatter of the next).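

Compound 2's 3-chlorophenyl is not matched by the larger 2,3-dimethoxyphenyl in this assay: the change gives a 16-fold higher number from compound 2 to compound 3 (1.20 log units; beyond the scatter). Against 4-methoxyphenyl, 2,3-dimethoxyphenyl gives a 1.3-fold higher number from compound 1 to compound 3 (0.12 log units; within the scatter), so the two methoxy-bearing groups cannot be told apart here, and among these compounds only 3-chlorophenyl stands out at this carbonyl carbon. Nothing available explains this difference. Still open, on these data alone, is whether the chlorine itself accounts for the advantage of compound 2, or whether a plain phenyl or a bromophenyl at this place would serve as well.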